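Estimating a 2,6-Difluorobenzyl Variant of Compound 1

The source may report more compounds than this note shows. Statements on the series, on what has been measured and on what is new or still open speak of the compounds shown alone.

Measured so far:
compound 1, `C=C1C(=O)O[C@H]2[C@H]1CC/C(COC(=O)Cn1cc(F)c(=O)n(Cc3ccccc3)c1=O)=C\CC[C@@]1(C)O[C@@H]21`: 3980 nM
compound 2, `C=C1C(=O)O[C@H]2[C@H]1CC/C(Cn1cc(Cn3cc(F)c(=O)n(Cc4ccccc4)c3=O)nn1)=C\CC[C@@]1(C)O[C@@H]21`: 9160 nM

In a functional assay on Bel-7402 cells (Homo sapiens) for antiproliferative activity, read by MTT assay, with a stated time of 72 h (a higher number here means a weaker inhibitor, a lower number a stronger inhibitor), compound 1 gives 3980 nM, the lowest of the two numbers shown. Compound 2 gives 9160 nM, a gap beyond the usual scatter. Compound 3, `C=C1C(=O)O[C@H]2[C@H]1CC/C(COC(=O)Cn1cc(F)c(=O)n(Cc3c(F)cccc3F)c1=O)=C\CC[C@@]1(C)O[C@@H]21`, differs from compound 1 in one place: 2,6-difluorophenyl in place of phenyl on a saturated chain carbon bound to an aromatic nitrogen. For the measured compounds named here, no pair of measured compounds shows how this change acts, and the piece has only compound 1 as a reference. The step of a 1.1-fold lower number from compound 1 to compound 3 (0.06 log units; within the scatter) is expected to be small, not beyond the scatter in either direction. Compound 3 is estimated at 3500 nM, with a range from 1400 nM to 9000 nM.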

Compound 3, half-maximal inhibitory concentration: 4500 nM
Compound 3: middle estimate off by 1.3-fold (0.11 log units), on the low side; low and high end bracket the measured number.
By their numbers in this assay, from the lowest: compounds 1 and 3 (each within the scatter of the next); then compound 2.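

In this assay, 2,6-difluorophenyl in place of phenyl on a saturated chain carbon bound to an aromatic nitrogen gives a 1.1-fold higher number from compound 1 to compound 3 (0.05 log units; within the scatter). For the compounds shown here, this is the first step measured at this position, and it shows that adding two fluorine atoms to the benzyl group leaves the read-out within the scatter. Nothing at hand explains this result. Going by these compounds, whether an amine or a carboxylic acid on the phenyl ring would move the number stays open. So does whether 2,6-difluorobenzyl would act the same way on compound 2.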